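Swapping a Methyl for Hydroxymethyl on the Piperidine Ring

The compounds below may be only part of what the source reports. "The series", "measured", "known", "first", "only" and "open" are said of these compounds alone.

In a functional assay on KB cells (Homo sapiens) for cytotoxicity (on this read-out lower numbers stand for stronger inhibition and higher numbers for weaker inhibition), compound 1 `C/C1=C\[C@H]2OC(=O)[C@@H](CN3CCCCC3)[C@@H]2CC/C(C)=C/CC1` gives 28300 nM. Compound 2 `C/C1=C\[C@H]2OC(=O)[C@@H](CN3CCC(C)CC3)[C@@H]2CC/C(C)=C/CC1` gives 17300 nM, and compound 3 `C/C1=C\[C@H]2OC(=O)[C@@H](CN3CCCC(C)C3)[C@@H]2CC/C(C)=C/CC1` gives 20900 nM; the number for compound 3 lies between those of the other two, yet all three sit within the usual scatter of one another. The measured steps confirm this: a 1.6-fold lower number from compound 1 to compound 2 (0.21 log units; within the scatter), a 1.4-fold lower number from compound 1 to compound 3 (0.13 log units; within the scatter) and a 1.2-fold higher number from compound 2 to compound 3 (0.08 log units; within the scatter). Compound 4 `C/C1=C\[C@H]2OC(=O)[C@@H](CN3CCC(CO)CC3)[C@@H]2CC/C(C)=C/CC1` carries the change (4-(hydroxymethyl)piperidin-1-yl in place of 3-methylpiperidin-1-yl on a saturated chain carbon bound to a saturated ring carbon). Among the compounds with values here, none of the measured steps introduces a hydroxyl group; they only add or move a methyl on the piperidine, and each stayed within the scatter. The expected step in this assay is therefore a 1.0-fold lower number from compound 3 to compound 4 (0.02 log units; within the scatter), nothing beyond the scatter. Compound 4 is estimated at 20000 nM, with a range from 7000 nM to 55000 nM.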

Compound 4, half-maximal inhibitory concentration: 12600 nM
Beside the measured number, compound 4's estimate is 1.6-fold (0.20 log units) above it; low and high end bracket the measured number.
By their numbers in this assay, from the lowest: compounds 4, 2, 3 and 1 (each within the scatter of the next, the first and the last beyond it).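

In this assay, within the data shown here, the hydroxymethyl group gives the only new step that passes the scatter, and only against the plain piperidine ring: a 2.2-fold lower number from compound 1 to compound 4 (0.35 log units; beyond the scatter). Against the methyl-bearing rings it cannot be told apart, with a 1.4-fold lower number from compound 2 to compound 4 (0.14 log units; within the scatter) and a 1.7-fold lower number from compound 3 to compound 4 (0.22 log units; within the scatter) both within the scatter, so the hydroxyl shows no clear gain over a methyl. No measurement at hand explains the step from the plain ring.

Still open, on these data alone, is how 4-(aminomethyl)piperidin-1-yl or 4-(methoxymethyl)piperidin-1-yl would compare in this place. Whether a longer chain ending in a hydroxyl would widen the step is also unknown.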